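Methyl for cyano beside the phenylsulfonyl group

The compounds below may be only part of what the source reports. "The series", "measured", "known", "first", "only" and "open" are said of these compounds alone.

Measured in a functional assay (Cavia porcellus) with sulfonylurea receptors; K-ATP channels (Homo sapiens) as the target; a lower number here means a stronger inhibitor, a higher number a weaker inhibitor:
compound 1 `CC(O)(C(=O)Nc1ccc(S(=O)(=O)c2ccccc2)c(C#N)c1)C(F)(F)F` gives 3800 nM
compound 2 `COc1cccc(S(=O)(=O)c2ccc(NC(=O)C(C)(O)C(F)(F)F)cc2)c1` gives 16000 nM

Among the compounds with values here, compound 1 stands lowest of the two numbers so far. Compound 2 sits clearly higher, and that gap lies beyond the usual scatter, so compound 1 is the stronger inhibitor of the two in this assay.

Compound 3 `Cc1cc(NC(=O)C(C)(O)C(F)(F)F)ccc1S(=O)(=O)c1ccccc1` keeps the shared core of compound 1 and differs from it in one place: methyl in place of cyano on an aromatic carbon. Within the data shown here, no pair of measured compounds shows this change, so its effect is not known from the numbers at hand. The author expects a modest step, most likely toward a somewhat higher number, and possibly no step beyond the scatter at all. The step from compound 1 to compound 3 is estimated as a 1.6-fold higher number from compound 1 to compound 3 (0.20 log units; within the scatter). For compound 3 the expected value in this assay is 6000 nM, with a range from 2000 nM to 20000 nM.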

Compound 3, half-maximal inhibitory concentration: 1600 nM
Beside the measured number, compound 3's estimate is 3.8-fold (0.57 log units) above it, and the stated range ends above it.
By their numbers in this assay, from the lowest: compound 3; then compound 1; then compound 2.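

In this assay, the aromatic carbon ortho to a phenylsulfonyl group now has its first one-place comparison: methyl in place of cyano gives a 2.4-fold lower number from compound 1 to compound 3 (0.38 log units; beyond the scatter). The nitrile is therefore not required at this position for inhibition, and the smaller methyl, with one heavy atom and no hydrogen-bond acceptor, serves better in this single pair. Nothing available explains why the number falls with this change.

The compounds shown leave open whether other groups at this position, such as chloro, ethyl, an amine or a carboxylic acid, would lower the number further or raise it again. They also leave open whether the same exchange would give a similar step on a core carrying the methoxy group of compound 2.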